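The compounds below may be only part of what the source reports. "The series", "measured", "known", "first", "only" and "open" are said of these compounds alone.

Measured in a functional assay on Caco-2 cells (Homo sapiens) for antiproliferative activity, read by MTT assay, with a stated time of 48 h; a higher number here means a weaker inhibitor, a lower number a stronger inhibitor:

compound 1, `CCn1c(C(=O)NCCN)ccc1C(CC)(CC)c1ccc(OCCC(O)(CC)CC)c(C)c1`: 1740 nM
compound 2, `CCn1c(C(=O)Nc2ccc(OC(F)(F)F)cc2)ccc1C(CC)(CC)c1ccc(OCCC(O)(CC)CC)c(C)c1`: only a limit is reported, > 50000 nM
compound 3, `CCn1c(C(=O)NC(CO)CCO)ccc1C(CC)(CC)c1ccc(OCCC(O)(CC)CC)c(C)c1`: 40200 nM

Compound 1 stands lowest of the two numbers given; its nearest neighbour is compound 3, reached by a 23-fold higher number from compound 1 to compound 3 (1.36 log units; beyond the scatter). For compound 2 the assay gives only (the limit of > 50000 nM in this assay, at which 1 of the 3 values shown sits), so the step of an at least 28-fold higher number from compound 1 to compound 2 (1.45 log units; beyond the scatter) is a floor rather than a size. Between compound 2 and compound 3 the step of an at least 1.2-fold lower number from compound 2 to compound 3 (0.09 log units; that floor lies within the scatter) lies within the scatter.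

Compound 4, `CCn1c(C(=O)NC(C)CO)ccc1C(CC)(CC)c1ccc(OCCC(O)(CC)CC)c(C)c1`, is not yet measured. It differs from compound 1 at the amide nitrogen: 1-(hydroxymethyl)ethyl in place of 2-aminoethyl on an amide-type nitrogen. Both measured steps from compound 1 bear on this change, since each also removes the 2-aminoethyl group from the amide nitrogen, and both were large in the direction of a higher number in this assay. The closer analogue is compound 3, where a hydroxyl-bearing group enters as it does here, with a 23-fold higher number from compound 1 to compound 3 (1.36 log units; beyond the scatter). A step upward beyond the scatter is therefore expected for compound 4, a 6.9-fold higher number from compound 1 to compound 4 (0.84 log units; beyond the scatter). The estimate for compound 4 in this assay is 12000 nM, with a range from 3500 nM to 45000 nM.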

Compound 4, half-maximal inhibitory concentration: > 50000 nM
Compound 4: a limit, no number (the forecaster's own chance of this, stated with the estimate: 15%); middle value at least 4.1-fold (0.61 log units) from the limit.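

In this assay compound 4 gives > 50000 nM, which is a limit and not a number. With 1-(hydroxymethyl)ethyl on the amide-type nitrogen the change gives an at least 28-fold higher number from compound 1 to compound 4 (1.45 log units; beyond the scatter), while the comparison with the other hydroxyl-bearing group gives an at least 1.2-fold higher number from compound 3 to compound 4 (0.09 log units; that floor lies within the scatter), so no difference between those two can be read, and compound 1, with its 2-aminoethyl group, stays beyond the scatter from all three other compounds in this series. The step between compound 2 and compound 4 cannot be read, since both rest on the same limit: the limit of > 50000 nM in this assay, at which 2 of the 4 values shown sit.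

Still open, from the compounds shown here alone, is whether the gap depends on the amine at the end of the 2-aminoethyl group or on the chain that carries it, which a 2-hydroxyethyl group, a 3-aminopropyl group or a 2-(dimethylamino)ethyl group on the same nitrogen would separate. Also open, going by these compounds, is how far compound 4 lies beyond its limit, and so where it stands against compound 3.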